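The compounds below may be only part of what the source reports. "The series", "measured", "known", "first", "only" and "open" are said of these compounds alone.

Measured compounds:
- compound 1 `COc1ccc(-c2cc3ccccc3nc2/C=C/C(=O)c2c(OC)cccc2OC)cc1`: 4710 nM
- compound 2 `COc1ccc(-c2cc3ccccc3nc2/C=C/C(=O)c2ccc(N)cc2)cc1`: 6510 nM
- compound 3 `COc1ccc(-c2cc3ccccc3nc2/C=C/C(=O)c2ccsc2)cc1`: 1220 nM

All three share one core and differ only in the group attached to the carbonyl carbon. In a functional assay on NCI-H1299 cells (Homo sapiens) for antiproliferative activity, read by XTT assay, with a stated time of 72 h (on this read-out higher numbers stand for weaker inhibition and lower numbers for stronger inhibition), compound 1 gives 4710 nM, the second highest of the three numbers. Its nearest neighbour is compound 2, with a 1.4-fold higher number from compound 1 to compound 2 (0.14 log units; within the scatter), so these two cannot be told apart. Compound 3 stands furthest away, with a 3.9-fold lower number from compound 1 to compound 3 (0.59 log units; beyond the scatter), and the same five-membered ring also gives a 5.3-fold lower number from compound 2 to compound 3 (0.73 log units; beyond the scatter).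

Compound 4 `COc1ccc(-c2cc3ccccc3nc2/C=C/C(=O)c2sccc2N)cc1` has not yet been tested in this assay. It differs from compound 1 as follows: 3-aminothiophen-2-yl in place of 2,6-dimethoxyphenyl on a carbonyl carbon

For the measured compounds named here, two measured steps bear on this. The move to a five-membered sulfur ring in compound 3 lowered the number modestly, by a 3.9-fold lower number from compound 1 to compound 3 (0.59 log units; beyond the scatter). Adding an amino group, as in compound 2, changed little, shown by a 1.4-fold higher number from compound 1 to compound 2 (0.14 log units; within the scatter). Compound 4 combines both features in one group, though the ring is joined at a different position than in compound 3, so the expectation is a modest drop of roughly the size seen for compound 3, not more.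

Compound 4 is therefore expected to give about 1800 nM in this assay, between 700 nM and 4500 nM, an estimated step of a 2.6-fold lower number from compound 1 to compound 4 (0.42 log units; beyond the scatter).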

Compound 4, half-maximal inhibitory concentration: > 10000 nM
Compound 4: a limit, no number; the forecaster's own chance of this, stated with the estimate: 5%; middle value at least 5.5-fold (0.74 log units) from the limit.
By their numbers in this assay, from the lowest: compound 3; then compounds 1 and 2 (each within the scatter of the next). At a limit, above all of these: compound 4.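

Compound 4 gives no number in this assay, only a limit, so every step to it is a floor: the limit of > 10000 nM in this assay, at which 1 of the 4 values shown sits.

At this position on the carbonyl carbon, a five-membered sulfur ring does not by itself bring the lower number seen for compound 3: swapping in 3-aminothiophen-2-yl gives an at least 8.1-fold higher number from compound 3 to compound 4 (0.91 log units; beyond the scatter), and against the 2,6-dimethoxyphenyl group it gives an at least 2.1-fold higher number from compound 1 to compound 4 (0.32 log units; beyond the scatter), the opposite direction to the step from compound 1 to compound 3. Against the 4-aminophenyl group there is an at least 1.5-fold higher number from compound 2 to compound 4 (0.18 log units; that floor lies within the scatter), so compound 4 is not firmly separated from compound 2, and both amino-bearing groups, unlike thiophen-3-yl, sit at the weak end of this small set.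

Compound 4 differs from compound 3 both in the amino group and in where the ring is joined, and these compounds cannot say which of the two matters. Going by these compounds, a plain thiophen-2-yl group with no amino group would separate those two changes, and the actual value of compound 4 beyond its limit remains unknown.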